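Iodo for acetyl: a step from compound 3 to compound 4

A few compounds are considered here, and "the series" means these few. Any claim that something is new, unique, unknown or untested is made for them only; others in the source may bear on it.

Measured so far:
compound 1, `CCc1ccc(NC(=O)N[C@H](C)c2ccccc2)cc1`: 44%
compound 2, `CC(C)c1ccc(NC(=O)N[C@H](C)c2ccccc2)cc1`: 49%
compound 3, `CC(=O)c1ccc(NC(=O)N[C@H](C)c2ccccc2)cc1`: 84%

In an ADME assay on the whole organism with Oryza sativa as the target, tested at 10 uM (a lower number here means a stronger effect, a higher number a weaker effect of the compound at the concentration tested), compound 3 stands highest of the three numbers. Its nearest neighbour is compound 2, and the step of a number 35 percentage points higher from compound 2 to compound 3 (beyond the scatter) lies beyond the scatter; the furthest is compound 1, with a number 40 percentage points higher from compound 1 to compound 3 (beyond the scatter), also beyond the scatter. The two alkyl-bearing compounds sit close to one another, as a number 5 percentage points higher from compound 1 to compound 2 (within the scatter) is within the scatter.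

Compound 4, `C[C@@H](NC(=O)Nc1ccc(I)cc1)c1ccccc1`, has not yet been measured. The change from compound 3 is:
iodo in place of acetyl on an aromatic carbon

Among the measured compounds shown here, no measured step involves iodo, so the bearing evidence is indirect. The two steps that replace an alkyl group with acetyl on the same aromatic carbon, a number 40 percentage points higher from compound 1 to compound 3 (beyond the scatter) and a number 35 percentage points higher from compound 2 to compound 3 (beyond the scatter), were both large and upward. Removing the acetyl again in compound 4, with iodo entering in its place, is therefore expected to move the number in this assay downward by a large amount, though the lack of any iodo-bearing comparison leaves the size uncertain. The expected step is a number 29 percentage points lower from compound 3 to compound 4 (beyond the scatter). Compound 4 is estimated at 55%, with a range from 35% to 78%.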

Compound 4, a percentage reported as activity, at one concentration (the size of the read-out at that concentration, not a potency): 85%
Estimate against measurement, compound 4: 30 percentage points below, outside the stated range (above it).
By their numbers in this assay, from the lowest: compounds 1 and 2 (each within the scatter of the next); then compounds 3 and 4 (each within the scatter of the next).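

In this assay, iodo on this aromatic carbon, para to a large group, does not lower the number as the alkyl groups do: the exchange for acetyl gives a number 1 percentage points higher from compound 3 to compound 4 (within the scatter), so the two groups cannot be told apart here, even though iodo brings 1 heavy atom and no hydrogen-bond acceptor where acetyl brought 3 heavy atoms and 1 hydrogen-bond acceptor. Set against the alkyl-bearing compounds, iodo gives a number 36 percentage points higher from compound 2 to compound 4 (beyond the scatter) and a number 41 percentage points higher from compound 1 to compound 4 (beyond the scatter), which shows that the high number at this position is not peculiar to acetyl or its carbonyl, and that among these four compounds only those with ethyl and isopropyl stand low. Nothing available explains why iodo and acetyl fall together and apart from the two alkyl groups.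

The compounds shown leave open whether the low numbers belong to alkyl groups in general, which a methyl group or a longer chain such as butyl on the same carbon would test. They also leave open where other groups would fall at this place, such as chloro, methoxy, an amine or a carboxylic acid, and so whether the high and low numbers form two distinct groups or the ends of a continuous range.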